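This account rests on a few compounds, and the source may have more. Where it says the series, first, only, none or still open, it means among the compounds named here.

Compound 1 `O=C(/C(=N/O)Nc1ccc(F)c(Br)c1)C1CCN(C(=O)NCc2ccccc2)CC1` is one of three compounds with a number in an assay for inhibition of Indoleamine 2,3-dioxygenase 1 (Homo sapiens), with a stated time of 1 h; on this read-out higher numbers stand for weaker inhibition and lower numbers for stronger inhibition. Compound 1 gives 43 nM, which places it second highest among the three. The nearest is compound 2 `O=C(/C(=N/O)Nc1ccc(F)c(Br)c1)[C@H]1CC[C@H](NS(=O)(=O)Nc2ccccc2)CC1`, which in this assay gives 102 nM, a higher number than compound 1 by a gap that lies beyond the usual scatter. The furthest is compound 3 `Cn1cc(-c2ccc(NC(=O)N3CCC(C(=O)/C(=N/O)Nc4ccc(F)c(Br)c4)CC3)cc2)cn1`, which in this assay gives 14 nM, a lower number than compound 1, again by a gap beyond the scatter.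

Compound 4 `O=C(/C(=N/O)Nc1ccc(F)c(Br)c1)C1CCN(S(=O)(=O)Nc2ccccc2)CC1` is the unmeasured compound. It keeps the shared core of compound 1 and differs in one place: phenylsulfamoyl in place of benzylcarbamoyl on an amine nitrogen in a ring. Compound 2 carries a phenylsulfamoyl group too, though on a ring of a different kind, and its number stands above that of compound 1.

No step between measured compounds is shown for this change, so the expectation for compound 4 rests on compound 2 and compound 1 alone. Because compound 2 gives 102 nM while compound 1 gives 43 nM, the expected step is a 1.9-fold higher number from compound 1 to compound 4 (0.27 log units; within the scatter), a somewhat higher number. Compound 4 is thus expected to give 80 nM, with a range from 30 nM to 220 nM.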

Compound 4, half-maximal inhibitory concentration: 98 nM
For compound 4 the middle estimate is 1.2-fold (0.09 log units) below the measured one, and the stated range covers the measured number.
By their numbers in this assay, from the lowest: compound 3; then compound 1; then compounds 4 and 2 (each within the scatter of the next).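

Within the shared core, phenylsulfamoyl in place of benzylcarbamoyl on an amine nitrogen in a ring gives, in this assay, a 2.3-fold higher number from compound 1 to compound 4 (0.36 log units; beyond the scatter), so this position responds to the change by a modest step. For the compounds shown here, the earlier compounds could not show this, as the only phenylsulfamoyl example among them sat on a ring of a different kind. With that group now on both rings, compound 4 at 98 nM and compound 2 at 102 nM stand within the scatter of each other, so these two compounds give no sign that the choice of ring matters; no measurement at hand accounts for the step from benzylcarbamoyl to phenylsulfamoyl.

The change alters both the linking group and the chain to the phenyl ring, and the compounds shown do not separate these two parts: a phenylcarbamoyl or a benzylsulfamoyl group at this position would be needed to tell them apart. Also open, going by these compounds, is how a phenylsulfamoyl group carrying a fluorine or a methoxy group on its phenyl ring would read at this position.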